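Compound 3 to compound 4: a chain-end exchange

The source may report more compounds than this note shows. Statements on the series, on what has been measured and on what is new or still open speak of the compounds shown alone.

Of the compounds shown here, three have been read in a functional assay on KB cells (Homo sapiens) for antiproliferative activity, read by MTT assay, with a stated time of 48 h (a higher number here means a weaker inhibitor, a lower number a stronger inhibitor), and none gives a number. Compound 1 (`Cn1cc(C2=C(c3nn(CCn4ccnc4)c4ncccc34)C(=O)N(c3ccccc3)C2=O)c2ccccc21`) gives > 100000 nM as a limit. Compound 2 (`Cn1cc(C2=C(c3nn(CCCN4CCCCC4)c4ncccc34)C(=O)N(c3ccccn3)C2=O)c2ccccc21`) gives > 100000 nM as a limit. Compound 3 (`CN1CCN(CCCn2nc(C3=C(c4cn(C)c5ccccc45)C(=O)NC3=O)c3cccnc32)CC1`) gives > 100000 nM as a limit. The whole set reads as follows: the limit of > 100000 nM in this assay, at which 3 of the 3 values shown sit. Within the data shown here, compound 3 therefore has no measured position relative to the other two, and no measured step is available to calibrate the next change.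

Compound 4 (`Cn1cc(C2=C(c3nn(CCCCn4ccnc4)c4ncccc34)C(=O)NC2=O)c2ccccc21`) replaces 4-methylpiperazin-1-yl with (1H-imidazol-1-yl)methyl on a saturated chain carbon, three bonds along the chain from an aromatic nitrogen: (1H-imidazol-1-yl)methyl in place of 4-methylpiperazin-1-yl on a saturated chain carbon, three bonds along the chain from an aromatic nitrogen. Read one bond further out, 3-(4-methylpiperazin-1-yl)propyl becomes 4-(1H-imidazol-1-yl)butyl.

The imidazole end offers little promise on its own, since compound 1 also carries a 1H-imidazol-1-yl group and gives > 100000 nM as a limit. The expected change is no step beyond the scatter, with any movement toward stronger inhibition, and the estimate for it is an at least 1.4-fold lower number from compound 3 to compound 4 (0.15 log units; that floor lies within the scatter). A further reading at the limit is quite possible. Compound 4 is expected at 70000 nM with an estimated range from 15000 nM to 100000 nM in this assay once measured.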

Compound 4, half-maximal inhibitory concentration: > 100000 nM
Compound 4: no number, only a limit; the forecaster's own chance of this, stated with the estimate: 60%; middle value at least 1.4-fold (0.15 log units) from the limit.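

Compound 3 and compound 4 are both limits rather than numbers in this assay, so the exchange of 4-methylpiperazin-1-yl for (1H-imidazol-1-yl)methyl gives no readable step, and the series stays flat: the limit of > 100000 nM in this assay, at which 4 of the 4 values shown sit.

The compounds shown leave open whether any change to the chain end or the shared core brings a measurable number in this assay.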